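The source may hold more compounds than are shown below. What is called first, only, known or untested is meant among the compounds shown, and "the series" means these compounds.

Measured compounds:
compound 1 `N/C(=N\O)c1ccc(C2=C(S(=O)(=O)c3ccc(Nc4cccc(/C(N)=N/O)c4)cc3)CC(c3ccccc3)(c3ccccc3)O2)cc1`: > 50000 nM
compound 2 `CC1(Cc2ccccc2)CC(S(=O)(=O)c2ccc(/C(N)=N/O)cc2)=C(c2ccc(Nc3cccc(/C(N)=N/O)c3)cc2)O1`: 44000 nM
compound 3 `N/C(=N\O)c1ccc(C2=C(S(=O)(=O)c3ccc(Nc4ccccc4/C(N)=N/O)cc3)CC(c3ccccc3)(c3ccccc3)O2)cc1`: > 50000 nM

The series is read in an ADME assay on THP-1 cells (Homo sapiens) for cytotoxicity, read by flow cytometry, with a stated time of 72 h; on this read-out higher numbers stand for weaker inhibition and lower numbers for stronger inhibition. For compound 1 the value > 50000 nM is a limit of the assay and not a number. For compound 3 the value > 50000 nM is likewise a limit. Among the measured compounds shown here, compound 2 gives 44000 nM, the only number in the set. The difference between the core of compound 1 and the core of compound 2 is not broken down here.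

From compound 1 to compound 3 the change is a group of 10 heavy atoms (7 carbon, 2 nitrogen, 1 oxygen; one six-membered aromatic ring of carbon only) in place of a group of 10 heavy atoms (7 carbon, 2 nitrogen, 1 oxygen; one six-membered aromatic ring of carbon only), on a nitrogen on an aromatic ring. The step that the two limits leave unreadable from compound 1 to compound 3 cannot be read, due to the limit of > 50000 nM in this assay, at which 2 of the 3 values shown sit. The same change is now made on the core of compound 2, giving compound 4 `CC1(Cc2ccccc2)CC(S(=O)(=O)c2ccc(/C(N)=N/O)cc2)=C(c2ccc(Nc3ccccc3/C(N)=N/O)cc2)O1`, with the difference (a group of 10 heavy atoms (7 carbon, 2 nitrogen, 1 oxygen; one six-membered aromatic ring of carbon only) in place of a group of 10 heavy atoms (7 carbon, 2 nitrogen, 1 oxygen; one six-membered aromatic ring of carbon only), on a nitrogen on an aromatic ring). The two place lines agree word for word, so the change is the same change on a different core.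

For the measured compounds named here, the only measured instance of this change gives no readable size, and compound 2 itself sits close to the limit that the other two compounds reach. Compound 4 is therefore expected to land near compound 2, with a step of about a 1.0-fold higher number from compound 2 to compound 4 (0.01 log units; within the scatter), resting on compound 2 at 44000 nM and on the unreadable step from compound 1 to compound 3. The estimate for compound 4 is 45000 nM, in the range 22000 nM to 90000 nM, with a fair chance that only a limit is returned.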

Compound 4, half-maximal inhibitory concentration: 48100 nM
Beside the measured number, compound 4's estimate is 1.1-fold (0.03 log units) below it; low and high end bracket the measured number.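

In this assay, the change on a nitrogen on an aromatic ring gives a 1.1-fold higher number from compound 2 to compound 4 (0.04 log units; within the scatter), so on the core of compound 2 the exchange of one group of 10 heavy atoms for the other leaves no readable difference. On the core of compound 1, the same change from compound 1 to compound 3 cannot be read, due to an assay limit that is not a number: the limit of > 50000 nM in this assay, at which 2 of the 4 values shown sit. The series therefore shows one readable instance of this change, which does not establish that the result carries from one core to another, since no size on the core of compound 1 is available for comparison, and it says nothing about a third core.

Left open is how this assay would read with a carboxylic acid or a nitrile on the aromatic ring in place of either group of 10 heavy atoms, with the core of compound 2 held fixed. Also open, from the compounds shown here alone, is whether a longer chain in place of the benzyl group on the core of compound 2 would give a number, and how far that number would lie from compound 2.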